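A Second Methyl on the Aryl Group of Compound 1

A few compounds are considered here, and "the series" means these few. Any claim that something is new, unique, unknown or untested is made for them only; others in the source may bear on it.

Compound 1 `Cc1ccc(-n2nc(-c3ccc(C(F)(F)F)cc3O)nc2-c2ccccc2O)cc1` gives 71.5% in a functional assay on PC-12 cells (Rattus norvegicus) for cytotoxicity, read by MTT assay, with stated times of 2 h and 24 h, tested at 1 uM (a lower number here means a weaker effect, a higher number a stronger effect of the compound at the concentration tested), the highest of the three numbers in hand, though compound 2 `Oc1cc(C(F)(F)F)ccc1-c1nc(-c2ccccc2O)n(-c2ccc(Br)cc2)n1` with 69.4% and compound 3 `Oc1cc(C(F)(F)F)ccc1-c1nc(-c2ccccc2O)n(-c2ccccc2F)n1` with 63.4% both lie within the scatter of it. Compound 4 `Cc1cc(C)cc(-n2nc(-c3ccc(C(F)(F)F)cc3O)nc2-c2ccccc2O)c1` differs from compound 1 by 3,5-dimethylphenyl in place of 4-methylphenyl on an aromatic nitrogen. The measured steps that bear on this change are the two at the same aromatic nitrogen, a number 8.1 percentage points lower from compound 1 to compound 3 (within the scatter) and a number 6 percentage points lower from compound 2 to compound 3 (within the scatter), while the replacement at an aromatic carbon, a number 2.1 percentage points lower from compound 1 to compound 2 (within the scatter), was likewise small. None of these moved the read-out beyond the scatter, so the expected step is a number 2.5 percentage points lower from compound 1 to compound 4 (within the scatter), not beyond the scatter. Compound 4 is therefore estimated at 69%, between 58% and 80%.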

Compound 4, a percentage reported as activity, at one concentration (the size of the read-out at that concentration, not a potency): 76.9%
Estimate against measurement, compound 4: 7.9 percentage points below; low and high end bracket the measured number.
By their numbers in this assay, from the lowest: compounds 3, 2, 1 and 4 (each within the scatter of the next, the first and the last beyond it).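

In this assay the aromatic nitrogen now shows a step beyond the scatter, a number 13.5 percentage points higher from compound 3 to compound 4 (beyond the scatter) with 3,5-dimethylphenyl in place of 2-fluorophenyl. The other two steps stay inside it, a number 5.4 percentage points higher from compound 1 to compound 4 (within the scatter) and a number 7.5 percentage points higher from compound 2 to compound 4 (within the scatter) so 3,5-dimethylphenyl cannot be told apart from 4-methylphenyl or 4-bromophenyl here. For the compounds shown here, nothing at hand explains the one larger step. The compounds shown leave open how an aryl group carrying an amine or a carboxylic acid would read at this nitrogen. They also leave open whether the order holds at other concentrations.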